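The compounds below may be only part of what the source reports. "The series", "measured", "known", "first", "only" and "open" are said of these compounds alone.

Working notes on the series. Compound 1 `Nc1cc(N)c2nc(-c3ccccc3)c(Oc3ccc(Cl)c(Cl)c3)nc2c1` is recorded in a functional assay on SK-OV-3 cells (Homo sapiens) for inhibition, read by sulforhodamine B assay, with a stated time of 48 h (on this read-out higher numbers stand for lower toxicity in this test and lower numbers for higher toxicity in this test), only as a limit, < 100000 nM. Compound 2 `COc1cc(CNc2nc3cc(N)cc(N)c3nc2-c2ccccc2)cc(OC)c1OC`, the other measured member, gives 36300 nM in this assay. Among the measured compounds shown here, no step between measured compounds can be drawn, because the result for compound 1 is a limit (the limit of < 100000 nM in this assay, at which 1 of the 2 values shown sits), and no structural difference between compound 1 and compound 2 is worked out here. Compound 3 `Nc1cc(N)c2nc(-c3ccccc3)c(Sc3ccc(F)cc3)nc2c1` remains to be measured; its structure departs from compound 1 by (4-fluorophenyl)sulfanyl in place of 3,4-dichlorophenoxy on an aromatic carbon. With compound 1 known only as a limit, no step size can be read from the numbers, and the step expected in this assay is a step that the limit leaves unreadable from compound 1 to compound 3, direction open and not expected beyond the usual scatter. Compound 3 is accordingly estimated in this assay at 40000 nM, with an expected range from 10000 nM to 100000 nM.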

Compound 3, concentration lethal to 50% of the cells: 63100 nM
Beside the measured number, compound 3's estimate is 1.6-fold (0.20 log units) below it; the range from low to high includes it.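

Among the compounds shown here, no step from compound 1 to compound 3 can be read in this assay, because the result for compound 1 is a limit: the limit of < 100000 nM in this assay, at which 1 of the 3 values shown sits. The compounds shown leave open whether (4-fluorophenyl)sulfanyl in place of 3,4-dichlorophenoxy on an aromatic carbon changes this read-out at all, and in which direction.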